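Swapping the ring on the carbonyl carbon, from compound 2 onward

The source may report more compounds than this note shows. Statements on the series, on what has been measured and on what is new or still open speak of the compounds shown alone.

Measured compounds:
compound 1 `COc1cc(-c2cc(/C=C/C(=O)c3ccc(N)cc3)[nH]n2)cc(OC)c1OC`: -58%
compound 2 `COc1cc(-c2cc(/C=C/C(=O)c3ccc(Cl)c(Cl)c3)[nH]n2)cc(OC)c1OC`: -13%
compound 3 `COc1ccc(-c2cc(/C=C/C(=O)c3cc(OC)c(OC)c(OC)c3)[nH]n2)cc1OC`: -62%

All three were tested in a functional assay on MDA-MB-468 cells (Homo sapiens) for cytotoxicity, read by sulforhodamine B assay, with a stated time of 48 h, tested at 10 uM; on this read-out higher numbers stand for a weaker effect at the one concentration tested and lower numbers for a stronger effect. Compound 2 stands highest of the three, that is, it shows the weakest effect, and both other compounds lie beyond the scatter below it. Among the compounds with values here, the one measured single-point step is a number 45 percentage points higher from compound 1 to compound 2 (beyond the scatter), a large weakening.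

Compound 4 `COc1ccc(C(=O)/C=C/c2cc(-c3cc(OC)c(OC)c(OC)c3)n[nH]2)cc1` differs from compound 2 by 4-methoxyphenyl in place of 3,4-dichlorophenyl on a carbonyl carbon. Within the data shown here, no measured step covers this exact exchange. Compound 3, whose ring on the carbonyl carbon also carries methoxy groups, gives -62%, which hints that leaving the dichlorophenyl should lower the number again. A step downward, a number 27 percentage points lower from compound 2 to compound 4 (beyond the scatter), is therefore expected for compound 4. Compound 4 is estimated at -40%, within -70% to -5%.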

Compound 4, a percentage reported as activity, at one concentration (the size of the read-out at that concentration, not a potency): -92%
For compound 4 the middle estimate is 52 percentage points above the measured one; measured number outside the range, below it.
By their numbers in this assay, from the lowest: compound 4; then compounds 3 and 1 (each within the scatter of the next); then compound 2.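

Within the data shown here, the 4-methoxyphenyl on the carbonyl carbon gives a number 79 percentage points lower from compound 2 to compound 4 (beyond the scatter) in this assay and the single exchange of amino for methoxy gives a number 34 percentage points lower from compound 1 to compound 4 (beyond the scatter) on the same read-out. One group on this ring can therefore shift the effect strongly even when the amino compound already reads low, so compound 1 did not mark the lowest number this position can reach. No measurement shown explains this shift. Still open, from the compounds shown here alone, is how a hydroxy group, a nitrile or a longer ether chain would read in place of the methoxy on this ring.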